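The source may hold more compounds than are shown below. What is called first, only, known or untested is meant among the compounds shown, and "the series" means these compounds.

In a physicochemical assay for solubility, using the shake flask method, in phosphate buffer, with a stated time of 24 h, at pH 7.4 (a lower number here means a less soluble compound, a higher number a more soluble compound), compound 1 `CC(Sc1nc2nn(CC3COC3)cc2c(=O)n1-c1ccccc1)c1ccccc1` gives 77000 nM and compound 2 `CC(Sc1nc2c(cnn2C)c(=O)n1-c1ccccc1)c1ccccn1` gives 20000 nM while compound 3 `Cn1ncc2c(=O)n(-c3ccccc3)c(CCc3cccc(F)c3)nc21` gives 126000 nM as its number. Compound 2 is the lowest of the three, with both others beyond the scatter. Compound 4 `CC(Sc1nc2c(cnn2C)c(=O)n1-c1ccccc1)c1ccccc1` differs from compound 2 in one place by phenyl in place of pyridin-2-yl on a saturated chain carbon bound to a saturated chain carbon and a sulfur with phenyl in place of pyridin-2-yl on a saturated chain carbon bound to a saturated chain carbon and a sulfur. Going by the values given here, no measured pair shows this change, so a moderate downward step in this assay is only an expectation, and compound 1, which also carries 1-phenylethyl, at 77000 nM argues against a large one. The expected size is a 2.0-fold lower number from compound 2 to compound 4 (0.30 log units; within the scatter) on this reasoning. Compound 4 is estimated at 10000 nM with a range of 3000 nM to 35000 nM in this measurement.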

Compound 4, solubility: 8000 nM
The estimate for compound 4 lay 1.3-fold (0.10 log units) above the measured number; measured number inside the range.
By their numbers in this assay, from the lowest: compound 4; then compound 2; then compounds 1 and 3 (each within the scatter of the next).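

In this assay, the exchange of pyridin-2-yl for phenyl on a saturated chain carbon bound to a saturated chain carbon and a sulfur gives a 2.5-fold lower number from compound 2 to compound 4 (0.40 log units; beyond the scatter) as the first step measured at this position. Going by these compounds alone, the step is modest but beyond the scatter, and it goes with the loss of the ring nitrogen, the only change between the two compounds. No measurement on hand accounts for this step. As far as these compounds go, whether pyridin-3-yl, an amine or a carboxylic acid at this place would give a higher or lower number remains open, as does whether the step holds on another core.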